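This account rests on a few compounds, and the source may have more. Where it says the series, first, only, none or still open, it means among the compounds named here.

The measured compounds:

Compound 1, `O=C(Nc1cccc(-n2cc(-c3ccncc3)c(-c3ccc(Cl)c(O)c3)n2)c1)Nc1cccc(C(F)(F)F)c1`: in a functional assay on A549 cells (Homo sapiens) for inhibition, read by sulforhodamine B assay, with a stated time of 48 h (on this read-out higher numbers stand for weaker inhibition of growth and lower numbers for stronger inhibition of growth), compound 1 gives > 32500 nM, which is a limit of the assay and not a number.
Compound 2, `COc1cc(-c2nn(-c3cccc(NC(=O)c4cccc(C(F)(F)F)c4)c3)cc2-c2ccncc2)ccc1Cl`: in this assay compound 2 gives > 50000 nM, again a limit.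
Compound 3, `COc1cc(-c2nn(-c3cccc(NC(=O)Nc4ccc(Cl)c(Cl)c4)c3)cc2-c2ccncc2)ccc1Cl`: in this assay compound 3 gives > 50000 nM, again a limit.

Compound 2 therefore stands at the limit of > 50000 nM in this assay, at which 2 of the 3 values shown sit, as does compound 3, while compound 1 sits at the limit of > 32500 nM in this assay, at which 1 of the 3 values shown sits. Going by the values given here, none of the three values shown is an actual number, so the only measured step, a step that the two limits leave unreadable from compound 2 to compound 3, cannot be read in size or direction. Compound 4, `COc1cc(-c2nn(-c3cccc(NC(=O)c4ccccc4)c3)cc2-c2ccncc2)ccc1Cl`, differs from compound 2 by hydrogen in place of trifluoromethyl on an aromatic carbon. Among the compounds with values here, with every neighbour at a limit, no measured step gives a size to expect for this change, and nothing suggests a move beyond the scatter. Compound 4 is expected to land at about 60000 nM, within 20000 nM to 200000 nM, most likely reported as a limit again. The expected step that the limit leaves unreadable from compound 2 to compound 4 is therefore essentially none.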

Compound 4, concentration for total growth inhibition: > 100000 nM
Compound 4 was reported as a limit (the forecaster's own chance of this, stated with the estimate: 80%); middle value at least 1.6-fold (0.22 log units) away from the limit.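

Compound 4 is reported as a limit, and compound 2 and compound 3 are limits too, so the steps linking compound 4 to them cannot be read. The compounds shown leave open whether this assay would separate any of them by an actual number.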